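Aryl substituent variation on the shared core

The compounds below may be only part of what the source reports. "The series", "measured", "known", "first", "only" and "open" are said of these compounds alone.

The series shares one core and varies the aryl group on the nitrogen on the aromatic ring. Compound 1 `C=CC(=O)Nc1cccc(NC(=O)CSc2nc(Nc3ccccc3F)c3ccccc3n2)c1` carries a 2-fluorophenyl group there; in a functional assay on NCI-H1975 cells (Homo sapiens) for inhibition, read by MTT assay, with a stated time of 72 h (a higher number here means a weaker inhibitor, a lower number a stronger inhibitor), compound 1 gives 6580 nM. Compound 2 `C=CC(=O)Nc1cccc(NC(=O)CSc2nc(Nc3ccccc3C)c3ccccc3n2)c1` carries a 2-methylphenyl group in its place; in this assay compound 2 gives 9920 nM. Within the data shown here, the one step measured so far is a 1.5-fold higher number from compound 1 to compound 2 (0.18 log units; within the scatter). On the two numbers shown, compound 2 stands at the top, but its separation from compound 1 is within the scatter, so the two are not distinguished.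

Compound 3 `C=CC(=O)Nc1cccc(NC(=O)CSc2nc(Nc3cccc(Br)c3)c3ccccc3n2)c1` differs from compound 2 by 3-bromophenyl in place of 2-methylphenyl on a nitrogen on an aromatic ring. Among the measured compounds shown here, only one step bears on this change, and it exchanges substituents at one place on the aryl group: a 1.5-fold higher number from compound 1 to compound 2 (0.18 log units; within the scatter), which shifted nothing beyond the scatter. For the measured compounds named here, no measured pair shows a substituent moved from one ring position to another, and none contains bromine. On this basis no step beyond the scatter is expected for compound 3 in this assay, and the estimated step is a 1.2-fold lower number from compound 2 to compound 3 (0.09 log units; within the scatter). For compound 3 the estimate in this assay is 8000 nM, with a range from 2500 nM to 25000 nM.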

Compound 3, half-maximal inhibitory concentration: 12100 nM
For compound 3 the middle estimate is 1.5-fold (0.18 log units) below the measured one; low and high end bracket the measured number.
By their numbers in this assay, from the lowest: compounds 1, 2 and 3 (each within the scatter of the next).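

In this assay, the exchange of 2-methylphenyl for 3-bromophenyl on the nitrogen on the aromatic ring is a 1.2-fold higher number from compound 2 to compound 3 (0.09 log units; within the scatter), and the exchange of 2-fluorophenyl for 3-bromophenyl is a 1.8-fold higher number from compound 1 to compound 3 (0.26 log units; within the scatter), so all three compounds now lie within the scatter of one another. Among these compounds, these are the first steps in which both the substituent and its location on the phenyl ring differ, and the first to bring in bromine, yet neither step separates compound 3 from compound 1 or compound 2. No supporting data bear on this result, so the absence of a distinguishable difference remains an observation without an explanation.

Each step to compound 3 changes the substituent and its ring location together, and the pairs shown do not separate those two changes. Also open, from the compounds shown here alone, is whether an amine or a carboxylic acid on the phenyl ring, or a longer alkyl chain on the nitrogen in place of the aryl group, would give a step beyond the scatter.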